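Methyl in place of hydrogen on the phenyl of compound 1

A few compounds are considered here, and "the series" means these few. Any claim that something is new, unique, unknown or untested is made for them only; others in the source may bear on it.

Compound 1 `CCOC(=O)C1=Cc2ccccc2OC1(OCc1cn(-c2ccccc2)nn1)C(F)(F)F` is tested in a functional assay on HeLa cells (Homo sapiens) for inhibition, read by MTT assay, with a stated time of 24 h (on this read-out lower numbers stand for stronger inhibition and higher numbers for weaker inhibition), and gives > 150000 nM, which is a limit of the assay and not a number. Compound 2 `O=C(O)C1=Cc2ccccc2OC1(OCc1cc(-c2cccc(C(F)(F)F)c2)no1)C(F)(F)F` also gives only a limit in this assay, > 150000 nM. Neither measured compound therefore yields a number; both sit at the limit of > 150000 nM in this assay, at which 2 of the 2 values shown sit. No step between two measured compounds with a single change is shown, so the series gives no measured size for any structural change.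

Compound 3 `CCOC(=O)C1=Cc2ccccc2OC1(OCc1cn(-c2ccc(C)cc2)nn1)C(F)(F)F` differs from compound 1 by methyl in place of hydrogen on an aromatic carbon. For this change in this assay no shift beyond the usual scatter is expected, in either direction; the step that the limit leaves unreadable from compound 1 to compound 3 is an estimate only. Compound 3 is accordingly expected to give about 250000 nM in this assay, within roughly 80000 nM to 800000 nM, most likely again as a limit rather than a number.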

Compound 3, half-maximal inhibitory concentration: 25100 nM
For compound 3 the middle estimate is 10-fold (1.00 log units) above the measured one; the measured number lies below the stated range.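

In this assay, within the data shown here, the change from phenyl to 4-methylphenyl gives an at least 5.9-fold lower number from compound 1 to compound 3 (0.77 log units; beyond the scatter), the first step that can be read at all. Compound 3 is also the first compound shown to give a number rather than a limit, so a single methyl on an aromatic carbon, para to a large group, is enough to bring this scaffold within the measurable range. The full size of the step remains unknown because compound 1 gives only a limit: the limit of > 150000 nM in this assay, at which 2 of the 3 values shown sit.

The compounds shown leave open whether this gain is specific to methyl or whether an ethyl chain or a methoxy group in the same place would lower the number further. They also leave open whether the same change would act similarly with a carboxylic acid in place of the ethyl ester.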